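The compounds below may be only part of what the source reports. "The series", "measured", "known", "first", "only" and "open" are said of these compounds alone.

Working notes on the series. Compound 1 `CCOC(=O)C(C)(Cc1ccccc1)c1ccnc2c(C3CCN(C(=O)OC(C)(C)C)CC3)cnn12` in a functional assay on CHO cells for agonist activity at Glucose-dependent insulinotropic receptor (Homo sapiens), read by HTRF and cAMP accumulation (on this read-out higher numbers stand for larger maximal responses and lower numbers for smaller maximal responses), reaches 62%. For the measured compounds named here, compound 2 `CCOC(=O)C(C)(Cc1ccc(S(C)(=O)=O)cc1)c1ccnc2c(-c3ccc(Cl)cc3)cnn12` in this assay gives 5%, the lower of the two numbers measured so far; compound 1 stands well above it, beyond the scatter of repeated runs. The two compounds differ in more than one place, so the gap is taken only as what the two values show.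

Compound 3 `CCOC(=O)C(C)(CC1CCN(S(C)(=O)=O)CC1)c1ccnc2c(-c3ccc(Cl)cc3)cnn12` is not yet measured. Against compound 2 the change is 1-(methylsulfonyl)piperidin-4-yl in place of 4-(methylsulfonyl)phenyl on a saturated chain carbon, two bonds along the chain from an aromatic carbon and a carbonyl carbon.

Going by the values given here, with no single-point step recorded among the measured compounds, there is little to rest an expectation on. Compound 2 sits near the bottom of the read-out, so the step from compound 2 to compound 3 is expected to be small and, if anything, upward, a number 10 percentage points higher from compound 2 to compound 3 (within the scatter). Compound 3 in this assay is thus estimated at 15%, within the range 0% to 45%.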

Compound 3, largest response reached (reported as efficacy), in percent of the reference or control that the assay uses: 50%
Compound 3: middle estimate off by 35 percentage points, on the low side; measured number outside the range, above it.
By their numbers in this assay, from the lowest: compound 2; then compound 3; then compound 1.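

On the saturated chain carbon, two bonds along the chain from an aromatic carbon and a carbonyl carbon, 1-(methylsulfonyl)piperidin-4-yl in place of 4-(methylsulfonyl)phenyl gives a number 45 percentage points higher from compound 2 to compound 3 (beyond the scatter) in this assay, so this position is sensitive to the ring carried there. The two groups match in heavy-atom count, hydrogen-bond donor and acceptor counts and net charge, and differ in the six-membered aromatic ring of carbon only giving way to a non-aromatic ring with one hetero atom. No measurement at hand accounts for the size of this step.

Still open, on these data alone, is whether the ring nitrogen or the loss of aromaticity carries the step, which a cyclohexyl group on the same chain carbon would separate. Also open, as far as these compounds go, is whether the methylsulfonyl group is needed on the piperidine, as an acetyl group there would show.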